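Iodo in place of phenyl on the shared core

The source may report more compounds than this note shows. Statements on the series, on what has been measured and on what is new or still open speak of the compounds shown alone.

Compound 2 `Cc1cc(-c2ccccc2)cn2c(CSCCc3ccccc3)cnc12` stands highest among the numbers measured in an ADME assay on HEL cells (Homo sapiens) for cytotoxicity, with a stated time of 3 days; a lower number here means that less compound is tolerated, a higher number that more compound is tolerated: compound 2 gives 31 ug/mL. For the measured compounds named here, compound 1 `c1ccc(CCSCc2cnc3ccc(-c4ccccc4)cn23)cc1` gives 9.9 ug/mL, and the step of a 3.1-fold higher number from compound 1 to compound 2 (0.50 log units; beyond the scatter) is the only measured step in the set. Compound 3 `Cc1cc(-c2cccs2)c2ncc(CSCCc3ccccc3)n2c1` sits at a limit of this assay, > 50 ug/mL, not at a number (the limit of > 50 ug/mL in this assay, at which 1 of the 3 values shown sits). Going by the values given here, only two numbers are therefore available, and compound 2 holds the higher of them.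

Compound 4 `Cc1cc(I)cn2c(CSCCc3ccccc3)cnc12` differs from compound 2 in one place: iodo in place of phenyl on an aromatic carbon. Among the compounds with values here, no measured step exchanges the phenyl for another group; the single measured step, a 3.1-fold higher number from compound 1 to compound 2 (0.50 log units; beyond the scatter), concerns a methyl and was modest, and compound 3 supplies no number. A direct guide for the exchange is thus missing. For compound 4 the expected step is a 1.1-fold higher number from compound 2 to compound 4 (0.05 log units; within the scatter), leaning toward more compound tolerated but with wide uncertainty. Compound 4 is estimated at 35 ug/mL, within 12 ug/mL to 50 ug/mL.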

Compound 4, half-maximal cytotoxic concentration: > 50 ug/mL
Compound 4 gave a limit, no number; the forecaster's own chance of this, stated with the estimate: 35%; at least 1.4-fold (0.15 log units) between middle value and limit.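

For the compounds shown here, exchanging phenyl for iodo on this aromatic carbon gives the first measured step at this position in this assay, and it is an at least 1.6-fold higher number from compound 2 to compound 4 (0.20 log units; that floor lies within the scatter). Compound 4 gives > 50 ug/mL, which is a limit and not a number. Going by these compounds alone, the phenyl ring at this place is therefore not required to keep the number from falling, although the floor of the step does not establish a real rise, and the only earlier step concerned a methyl elsewhere on the shared core.

As far as these compounds go, how far compound 4 truly lies past its limit stays open, and the read-out gives no further separation at that end: the limit of > 50 ug/mL in this assay, at which 2 of the 4 values shown sit. Whether an amine or a carboxylic acid on this same aromatic carbon would hold the number at that level also stays open.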